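Series notes: amide-nitrogen chain change from compound 2 to compound 4

The source may hold more compounds than are shown below. What is called first, only, known or untested is meant among the compounds shown, and "the series" means these compounds.

Measured so far:
compound 1 `Cc1cnc(CN2CC(=O)N(CC(C)C)c3c(Cl)nc(N)nc32)c(C)c1Br`: 280 nM
compound 2 `COc1c(C)cnc(CN2CC(=O)N(CC(C)C)c3c(Cl)nc(N)nc32)c1C`: 70 nM
compound 3 `COc1c(C)cnc(CN2c3nc(N)nc(Cl)c3NC(=O)[C@@H]2CC(C)C)c1C`: 930 nM

In a functional assay on MCF7 cells (Homo sapiens) for inhibition (on this read-out higher numbers stand for weaker inhibition and lower numbers for stronger inhibition), compound 2 gives the lowest of the three numbers, with compound 1 next and compound 3 furthest away. Within the data shown here, the one measured step at a single position, a 4.0-fold lower number from compound 1 to compound 2 (0.60 log units; beyond the scatter), concerns the aromatic ring. Compound 2 and compound 3 differ in more than one place, so their values are only compared, not resolved into a step.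

Compound 4 `COc1c(C)cnc(CN2CC(=O)N(CCN3CCCC3)c3c(Cl)nc(N)nc32)c1C` is the unmeasured analogue. Its change from compound 2 is (pyrrolidin-1-yl)methyl in place of isopropyl on a saturated chain carbon bound to an amide-type nitrogen in a ring. Among the measured compounds shown here, none of the measured steps touches the saturated chain on the amide-type nitrogen in the ring, so there is no direct precedent for this change; the one measured step gives no guidance on direction here. In the absence of a bearing step, only a small or moderate shift is expected, and the uncertainty is wide. The estimate for compound 4 in this assay is 150 nM, within 40 nM to 600 nM, corresponding to an expected step of a 2.1-fold higher number from compound 2 to compound 4 (0.33 log units; beyond the scatter).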

Compound 4, half-maximal inhibitory concentration: 1320 nM
For compound 4 the middle estimate is 8.8-fold (0.94 log units) below the measured one; measured number above the stated range.
By their numbers in this assay, from the lowest: compound 2; then compound 1; then compounds 3 and 4 (each within the scatter of the next).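

In this assay, among these compounds, the change from isobutyl to 2-(pyrrolidin-1-yl)ethyl gives a 19-fold higher number from compound 2 to compound 4 (1.28 log units; beyond the scatter), the first reading for the saturated chain on the amide-type nitrogen in the ring. This chain is therefore not a neutral position: this one replacement, which brings in a five-membered non-aromatic ring with 1 hetero atom, goes with clearly weaker inhibition. No supporting data bear on what drives the loss, and the added nitrogen, the ring and the larger group remain unseparated.

The compounds shown leave open how a 2-cyclopentylethyl chain, which keeps a ring but has no nitrogen, would read against compound 2. They also leave open whether an open-chain amine such as 2-(diethylamino)ethyl, or a longer chain ending in pyrrolidine, would follow compound 4.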